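Replacing 4-methoxyphenyl with 4-chlorophenyl: working notes

A few compounds are considered here, and "the series" means these few. Any claim that something is new, unique, unknown or untested is made for them only; others in the source may bear on it.

Measured in a functional assay on DU-145 cells (Homo sapiens) for cytotoxicity, read by MTT assay, with a stated time of 48 h; a higher number here means a weaker inhibitor, a lower number a stronger inhibitor
- compound 1 `COc1ccc(-c2nc3ccccn3c2C(=O)/C=C\Nc2cc(OC)cc(OC)c2)cc1` gives 6260 nM
- compound 2 `COc1ccc(-c2nc3ccccn3c2C(=O)/C=C\Nc2ccc3cc[nH]c3c2)cc1` gives 10700 nM
- compound 3 `COc1ccc(-c2nc3ccccn3c2C(=O)/C=C\Nc2ccc3ncccc3c2)cc1` gives 4720 nM

Compound 1 stands among the three numbers, with neither step from it leaving the scatter (a 1.7-fold higher number from compound 1 to compound 2 (0.23 log units; within the scatter)) and (a 1.3-fold lower number from compound 1 to compound 3 (0.12 log units; within the scatter)). Only the remaining pair separates, and modestly (a 2.3-fold lower number from compound 2 to compound 3 (0.36 log units; beyond the scatter)).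

Compound 4 `COc1cc(N/C=C\C(=O)c2c(-c3ccc(Cl)cc3)nc3ccccn23)cc(OC)c1` carries chloro in place of methoxy on an aromatic carbon, para to a large group, so 4-chlorophenyl replaces 4-methoxyphenyl (chloro in place of methoxy on an aromatic carbon). All three measured steps change the group on the amine nitrogen, so none tests this position directly. They bear on it only by showing the size of steps seen so far in the series. No step beyond the scatter is therefore expected in this assay, and the data favour no direction. The estimated step is small (a 1.1-fold lower number from compound 1 to compound 4 (0.06 log units; within the scatter)), with wide uncertainty. Compound 4 is estimated at 5500 nM (expected range 2200 nM to 13000 nM).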

Compound 4, half-maximal inhibitory concentration: 12000 nM
Beside the measured number, compound 4's estimate is 2.2-fold (0.34 log units) below it; measured number inside the range.
By their numbers in this assay, from the lowest: compounds 3, 1, 2 and 4 (each within the scatter of the next, the first and the last beyond it).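

For the compounds shown here, this is the first direct reading of the 4-methoxyphenyl position on the shared core. With the 3,5-dimethoxyphenyl group on the amine nitrogen held fixed, in this assay the exchange of methoxy for chloro gives a 1.9-fold higher number from compound 1 to compound 4 (0.28 log units; within the scatter) and so does not separate the two compounds. On this single pair, the position accepts the exchange with no step beyond the scatter, and no measurement shown accounts for the size of this step.

On these data alone, whether 4-chlorophenyl reads the same way with quinolin-6-yl or 1H-indol-6-yl on the amine nitrogen remains open. Also open, as far as these compounds go, is how other groups at this place on the ring, such as an amine, a carboxylic acid or fluoro, would read.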